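Ring-substituent swaps in an antiproliferative sulfonamide series

The source may report more compounds than this note shows. Statements on the series, on what has been measured and on what is new or still open speak of the compounds shown alone.

Compound 2 `COc1cc(CC2C(C#N)=C(N)N(c3ccc(S(N)(=O)=O)cc3)C3=C2C(=O)CCC3)ccc1O` gives 50% in a functional assay on Ehrlich cells (Mus musculus) for antiproliferative activity, read by trypan blue exclusion, with a stated time of 2 h, tested at 25 ug/mL; on this read-out higher numbers stand for a stronger effect at the one concentration tested and lower numbers for a weaker effect. Compound 1 `COc1ccc(C2C(C#N)=C(N)N(c3ccc(S(N)(=O)=O)cc3)C3=C2C(=O)CCC3)cc1` gives 50% there, so compound 2 sits level with compound 1, and the step of no change at the digits printed from compound 1 to compound 2 (within the scatter). Compound 3 `COc1ccc2ccccc2c1C1C(C#N)=C(N)N(c2ccc(S(N)(=O)=O)cc2)C2=C1C(=O)CCC2` gives 62%; here a number 12 percentage points higher from compound 2 to compound 3 (beyond the scatter) and a number 12 percentage points higher from compound 1 to compound 3 (beyond the scatter), so the two lower numbers stand below compound 3. Compound 4 `N#CC1=C(N)N(c2ccc(S(N)(=O)=O)cc2)C2=C(C(=O)CCC2)C1c1ccco1` has not been measured; it carries the change (furan-2-yl in place of 4-hydroxy-3-methoxybenzyl on a saturated ring carbon). The measured steps at this saturated ring carbon were either within the scatter or modest, so no large step is expected in this assay. For compound 4 a value of 50% is estimated, with a range from 38% to 64%. The step of no change at the digits printed from compound 2 to compound 4 (within the scatter) is therefore expected to fall within the scatter.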

Compound 4, a percentage reported as activity, at one concentration (the size of the read-out at that concentration, not a potency): 0%
Estimate against measurement, compound 4: 50 percentage points above; the measured number lies below the stated range.
By their numbers in this assay, from the lowest: compound 4; then compounds 1 and 2 (each within the scatter of the next); then compound 3.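

With furan-2-yl on this saturated ring carbon, this assay shows a number 50 percentage points lower from compound 2 to compound 4 (beyond the scatter), a number 50 percentage points lower from compound 1 to compound 4 (beyond the scatter) and a number 62 percentage points lower from compound 3 to compound 4 (beyond the scatter). Within the data shown here, the position is therefore not as forgiving as the earlier steps among compounds 1, 2 and 3 suggested: the group here can remove the read-out altogether at the one concentration tested. Nothing at hand accounts for this loss.

From the compounds shown here alone, whether the loss follows the furan ring itself or the lack of a methoxy group remains open. A thiophen-2-yl or a methoxy-bearing furan-2-yl on this carbon would separate the two.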